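The source may report more compounds than this note shows. Statements on the series, on what has been measured and on what is new or still open speak of the compounds shown alone.

In an assay on isolated protein for inhibition of leukotriene B4 receptor 1 (Homo sapiens), tested at 10 uM (on this read-out lower numbers stand for less inhibition and higher numbers for more inhibition at the one concentration tested (going by the name of the read-out)), compound 1 `CCc1cc(C(C)=O)c(O)cc1OCCCCCCC(C)(C)C#N` gives 65%. Going by the values given here, that is the higher of the two numbers measured so far: compound 2 `C=CCc1cc(C(C)=O)c(O)cc1OCCCCO` gives 48%, a result lower by more than the usual scatter, so compound 1 stands clearly above it. Among the compounds with values here, no pair of measured compounds differing in just one place is available, so there is no measured step to guide the next move.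

Compound 3 `CCc1cc(C(C)=O)c(O)cc1OCCCCCCS(C)(=O)=O` has not yet been measured. It differs from compound 1 in one place: methylsulfonyl in place of 1-cyano-1-methylethyl on a saturated chain carbon, six bonds along the chain from an oxygen on an aromatic ring. Both the group that leaves and the group that enters carry no hydrogen-bond donors. Without a measured step of this kind, only a modest change is expected, most likely a small drop that may well stay within the scatter, and the expected step in this assay is a number 10 percentage points lower from compound 1 to compound 3 (within the scatter). Compound 3 is therefore estimated to give about 55%, within a range from 35% to 75%.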

Compound 3, a percentage reported as inhibition, at one concentration (the size of the read-out at that concentration, not a potency): 99%
For compound 3 the middle estimate is 44 percentage points below the measured one; measured number outside the range, above it.
By their numbers in this assay, from the lowest: compound 2; then compound 1; then compound 3.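

In this assay the group at this place turns out to matter a great deal: with the rest of compound 1 unchanged, methylsulfonyl in place of 1-cyano-1-methylethyl gives a number 34 percentage points higher from compound 1 to compound 3 (beyond the scatter), a large step. The place on a saturated chain carbon, six bonds along the chain from an oxygen on an aromatic ring, is therefore sensitive to what sits there, even though neither group carries a hydrogen-bond donor. Nothing available explains why this change has so large an effect.

The compounds shown leave open whether an amine or a carboxylic acid at the same place would match methylsulfonyl, and whether a longer chain would keep the gain. A read-out at one concentration also does not tell how potent compound 3 is.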